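The compounds below may be only part of what the source reports. "The series", "measured", "known", "first", "only" and "open" are said of these compounds alone.

Working notes on the series. Compound 1, `CC(C)OC(=O)N1CCC(O[C@H]2CC[C@H](Oc3cnc(S(C)(=O)=O)cn3)CC2)CC1`, carries an isopropyl on an oxygen next to a carbonyl group; in a functional assay on isolated protein for agonist activity at Glucose-dependent insulinotropic receptor (Rattus norvegicus), read by HTRF and cAMP accumulation (on this read-out lower numbers stand for an effect already at smaller amounts and higher numbers for an effect only at larger amounts of compound), compound 1 gives 119 nM. Compound 2, `CC1(OC(=O)N2CCC(O[C@H]3CC[C@H](Oc4cnc(S(C)(=O)=O)cn4)CC3)CC2)CC1`, differs in one place, 1-methylcyclopropyl in place of isopropyl on an oxygen next to a carbonyl group, and in this assay compound 2 gives 138 nM. The step of a 1.2-fold higher number from compound 1 to compound 2 (0.06 log units; within the scatter) lies within the scatter. Of the two numbers shown, that of compound 2 is the larger, but its gap to compound 1 is within the scatter, so the two are not distinguished.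

Compound 3, `C[C@H](CF)OC(=O)N1CCC(O[C@H]2CC[C@H](Oc3cnc(S(C)(=O)=O)cn3)CC2)CC1`, is not yet measured. Its change from compound 2: 1-(fluoromethyl)ethyl in place of 1-methylcyclopropyl on an oxygen next to a carbonyl group. Among the measured compounds shown here, the only measured step at this oxygen, a 1.2-fold higher number from compound 1 to compound 2 (0.06 log units; within the scatter), exchanged one small substituent for another and left the number within the scatter. Compound 3 again exchanges one small substituent for another at the same place, now with a fluorine among its atoms. No step beyond the scatter is therefore expected. The estimate for compound 3 in this assay is 130 nM. For compound 3 the expected range runs from 60 nM to 280 nM. This estimate means an expected step of a 1.1-fold lower number from compound 2 to compound 3 (0.03 log units; within the scatter), within the scatter.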

Compound 3, half-maximal effective concentration: 317 nM
The estimate for compound 3 lay 2.4-fold (0.39 log units) below the measured number; the measured number lies above the stated range.
By their numbers in this assay, from the lowest: compounds 1 and 2 (each within the scatter of the next); then compound 3.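

In this assay, the position on an oxygen next to a carbonyl group is not indifferent to every exchange of one small substituent for another: 1-(fluoromethyl)ethyl in place of 1-methylcyclopropyl gives a 2.3-fold higher number from compound 2 to compound 3 (0.36 log units; beyond the scatter), whereas the earlier exchange gave only a 1.2-fold higher number from compound 1 to compound 2 (0.06 log units; within the scatter). The closest comparison is fluoro in place of hydrogen on a saturated chain carbon, two bonds along the chain from that oxygen, which gives a 2.7-fold higher number from compound 1 to compound 3 (0.43 log units; beyond the scatter), so this single replacement is enough to carry the number beyond the scatter, though only by a modest step. Nothing at hand bears on why the number moves in this way.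

The compounds shown leave open whether the step belongs to fluorine as such or to the defined stereocentre that enters with 1-(fluoromethyl)ethyl, since the opposite configuration at that centre does not stand among them. They also leave open how the number responds at this oxygen to a 1-(difluoromethyl)ethyl group, a tert-butyl group or a 1-(methoxymethyl)ethyl group.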